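Methoxy step in a small cytotoxicity series

A few compounds are considered here, and "the series" means these few. Any claim that something is new, unique, unknown or untested is made for them only; others in the source may bear on it.

Measured in a functional assay on HT-29 cells (Homo sapiens) for cytotoxicity, read by MTT assay, with a stated time of 6 days; a higher number here means that more compound is needed for the effect, a lower number that less compound is needed:
compound 1, `COC(=O)c1c(-c2ccc(O)cc2)oc2ccccc2c1=O`: > 25 ug/mL (a limit, not a number)
compound 2, `COC(=O)c1c(-c2ccc(O)cc2)oc2cc(OC)ccc2c1=O`: 19.2 ug/mL
compound 3, `O=C(O)c1c(-c2ccc([N+](=O)[O-])cc2)oc2ccccc2c1=O`: > 25 ug/mL (a limit, not a number)

Compound 1 gives > 25 ug/mL, which is a limit rather than a number. Compound 2 gives 19.2 ug/mL. The change between them is methoxy in place of hydrogen on an aromatic carbon, and the step is an at least 1.3-fold lower number from compound 1 to compound 2 (0.11 log units; that floor lies within the scatter). Compound 3 gives > 25 ug/mL, again a limit. How the core of compound 3 differs from the core of compound 1 is not broken down here. Across the values shown, (the limit of > 25 ug/mL in this assay, at which 2 of the 3 values shown sit).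

Compound 4, `COc1ccc2oc(-c3ccc([N+](=O)[O-])cc3)c(C(=O)O)c(=O)c2c1`, is not yet measured. It carries the same change as the measured pair, (methoxy in place of hydrogen on an aromatic carbon), at the same place word for word. The expected step in this assay is an at least 1.1-fold lower number from compound 3 to compound 4 (0.05 log units; that floor lies within the scatter), a size in line with an at least 1.3-fold lower number from compound 1 to compound 2 (0.11 log units; that floor lies within the scatter), starting from a limit. Compound 4 is expected to give 22 ug/mL, between 12 ug/mL and 40 ug/mL, with a real chance that only a limit is reported again.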

Compound 4, concentration for half-maximal effect: > 25 ug/mL
Compound 4: only a limit was reported; the forecaster's own chance of this, stated with the estimate: 50%; middle value at least 1.1-fold (0.05 log units) away from the limit.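

Compound 3 and compound 4 both give only limits in this assay, and the step between them cannot be read. Left open is whether methoxy in place of hydrogen changes the number at all on the core of compound 3.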